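Trimming a Ring Down to a Methyl on a Macrolide Amide

The source may hold more compounds than are shown below. What is called first, only, known or untested is meant among the compounds shown, and "the series" means these compounds.

Measured so far, in a physicochemical assay for lipophilicity, read by HPLC, measured as chromatographic lipophilicity, at pH 7.4; a lower number here means a more polar compound, a higher number a more lipophilic compound:
compound 1 `CC[C@H]1OC(=O)[C@H](C)[C@@H](O[C@H]2C[C@@](C)(OC)[C@@H](OCCCNC(=O)C3CCC3)[C@H](C)O2)[C@H](C)[C@@H](O[C@@H]2O[C@H](C)C[C@H](N(C)C)[C@H]2O)[C@](C)(O)C[C@@H](C)CN(C)[C@H](C)[C@@H](O)[C@]1(C)O` gives 2.62
compound 2 `CCCCC(=O)NCCCO[C@@H]1[C@@H](C)N(C)C[C@H](C)C[C@@](C)(O)[C@H](O[C@@H]2O[C@H](C)C[C@H](N(C)C)[C@H]2O)[C@@H](C)[C@H](O[C@H]2C[C@@](C)(OC)[C@@H](O)[C@H](C)O2)[C@@H](C)C(=O)O[C@H](CC)[C@@]1(C)O` gives 3.74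
compound 3 `CC[C@H]1OC(=O)[C@H](C)[C@@H](O[C@H]2C[C@@](C)(OC)[C@@H](O)[C@H](C)O2)[C@H](C)[C@@H](O[C@@H]2O[C@H](C)C[C@H](N(C)C)[C@H]2OCCCNC(=O)COC)[C@](C)(O)C[C@@H](C)CN(C)[C@H](C)[C@@H](O)[C@]1(C)O` gives 2.54

All three share the same large macrolide core and differ in the side chain carried on one of its sugars. Among the three numbers, compound 1 sits second highest. Its value and that of compound 3 lie within the usual scatter of this assay, so no order between them can be claimed. Compound 2 stands clearly apart, with a number beyond the scatter higher than compound 1.

The new compound 4 `CC[C@H]1OC(=O)[C@H](C)[C@@H](O[C@H]2C[C@@](C)(OC)[C@@H](OCCCNC(C)=O)[C@H](C)O2)[C@H](C)[C@@H](O[C@@H]2O[C@H](C)C[C@H](N(C)C)[C@H]2O)[C@](C)(O)C[C@@H](C)CN(C)[C@H](C)[C@@H](O)[C@]1(C)O` is built from compound 1 by one change at the amide end of the side chain: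

methyl in place of cyclobutyl on a carbonyl carbon

Among the measured compounds shown here, no measured pair in this set shows the same change, so its size has to be estimated from the counts alone. The change takes away four carbon atoms in a ring and puts back a single carbon, and in this assay such a loss of carbon would be expected to move the number downward by a step beyond the scatter. For compound 4 the estimated step of a number 0.67 log units lower from compound 1 to compound 4 (beyond the scatter) leads to an expected value of 1.95, with a range from 1.5 to 2.4.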

Compound 4, distribution coefficient: 2.06
Compound 4: middle estimate off by 0.11 log units, on the low side; low and high end bracket the measured number.
By their numbers in this assay, from the lowest: compound 4; then compounds 3 and 1 (each within the scatter of the next); then compound 2.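

In this assay, methyl in place of cyclobutyl on a carbonyl carbon gives a number 0.56 log units lower from compound 1 to compound 4 (beyond the scatter) and so shows that the number responds to what sits at the amide end of this side chain. Compounds 1 and 4 form the first pair shown that differs in one place only, which allows a single change to be read directly rather than through differences spread across the structures. Neither the group that leaves nor the group that enters has any hydrogen-bond donors or acceptors or a net charge, and no measurement here explains the size of the step.

Other groups on the same carbonyl carbon, such as ethyl, cyclopropyl or a longer straight chain, would show whether the step follows the number of carbons or depends on the four-membered ring itself. As far as these compounds go, it also remains open how an amine or a carboxylic acid at this end of the side chain would read, and whether the change from cyclobutyl to methyl gives a similar step when the side chain is attached elsewhere on the shared core.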